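Swapping a Methoxyphenyl Arm for a Naphthalene Arm

The compounds below may be only part of what the source reports. "The series", "measured", "known", "first", "only" and "open" are said of these compounds alone.

Of the compounds shown here, two with a shared core have been tested in a functional assay on HT-29 cells (Homo sapiens) for cytotoxicity, read by MTT assay, with a stated time of 72 h; a lower number here means a stronger inhibitor, a higher number a weaker inhibitor. Compound 1 `O=C1CS/C(=N\c2csc(-c3ccccc3)c2)N1` is the simpler of the two, and in this assay compound 1 gives > 50000 nM, which is a limit of the assay rather than a number; this is the situation described by the limit of > 50000 nM in this assay, at which 1 of the 2 values shown sits. Compound 2 `COc1ccc(/C=C2\S/C(=N\c3csc(-c4ccc(Cl)cc4)c3)NC2=O)cc1` carries a 4-chlorophenyl group and a 4-methoxyphenyl group, and in this assay compound 2 gives 3800 nM, the only number among the two results shown, so compound 2 stands as the single compound with a measured value here. Compound 3 `O=C1N/C(=N/c2csc(-c3ccc(Cl)cc3)c2)S/C1=C\c1ccc2ccccc2c1` has not yet been measured. It differs from compound 2 in one place: naphthalen-2-yl in place of 4-methoxyphenyl on a double-bonded chain carbon bound to a double-bonded ring carbon. No step between two measured compounds is shown, so nothing tells how an exchange of this kind has moved the numbers before. With one flat ring system replacing another, the step from compound 2 to compound 3 is estimated as a 1.3-fold lower number from compound 2 to compound 3 (0.10 log units; within the scatter), a shift expected to stay close to the scatter. Compound 3 is therefore expected to give about 3000 nM in this assay, with a range from 800 nM to 12000 nM.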

Compound 3, half-maximal inhibitory concentration: 3700 nM
For compound 3 the middle estimate is 1.2-fold (0.09 log units) below the measured one, within the range that was stated.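

In this assay, this first measured step at the position, on a double-bonded chain carbon bound to a double-bonded ring carbon, reads a 1.0-fold lower number from compound 2 to compound 3 (0.01 log units; within the scatter). In this one pair, then, 4-methoxyphenyl and naphthalen-2-yl cannot be told apart, even though the exchange removes the hydrogen-bond acceptor of the arm and adds a second six-membered aromatic ring. Nothing measured here explains why the two arms read alike.

Both arms contain aromatic rings of carbon only, so the compounds shown leave open how this assay would respond at this place to a carboxylic acid, an amine or a longer saturated chain. Also open, as far as these compounds go, is how much of the result for compound 2 and compound 3 depends on having an arm here at all: compound 1 differs from both in more than one place, so its result, which is a limit of the assay and not a number, cannot settle that.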